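The source may report more compounds than this note shows. Statements on the series, on what has been measured and on what is new or still open speak of the compounds shown alone.

Measured so far in an in vitro assay on CHOk1 cells with adenosine receptor A1 (Homo sapiens) as the target; a lower number here means that less compound is needed, a higher number that more compound is needed for the effect:
compound 1 `Nc1sc2c(c1C(=O)NCc1ccccc1)CCN(Cc1ccccc1)C2` — 13100 nM
compound 2 `Nc1sc2c(c1C(=O)NCc1cccc(Cl)c1)CCN(Cc1ccccc1)C2` — > 20000 nM
compound 3 `NNC(=O)c1c(N)sc2c1CCN(Cc1ccccc1)C2` — 8900 nM

Compound 3 holds the lowest of the two numbers in this assay, with compound 1 nearest; the step of a 1.5-fold lower number from compound 1 to compound 3 (0.17 log units; within the scatter) stays within the scatter, so neither is called the stronger. Compound 2 gives no number but only (the limit of > 20000 nM in this assay, at which 1 of the 3 values shown sits). From that limit, an at least 2.2-fold lower number from compound 2 to compound 3 (0.35 log units; beyond the scatter) counts as at least modest, and an at least 1.5-fold higher number from compound 1 to compound 2 (0.18 log units; that floor lies within the scatter) is only a floor.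

Compound 4 `CN1CCc2c(sc(N)c2C(=O)NN)C1` differs from compound 3 in one place: hydrogen in place of phenyl on a saturated chain carbon bound to an amine nitrogen in a ring. All three measured steps change the group on the amide-type nitrogen and leave the benzyl on the ring amine untouched, so none of them bears on this change. The series gives no measured size for a step at this position; the working expectation is a change that stays within the scatter or runs modestly higher, with a wide range to either side. Compound 4 is expected to give 12000 nM, between 3000 nM and 40000 nM in this assay. The step of a 1.3-fold higher number from compound 3 to compound 4 (0.13 log units; within the scatter) is thus estimated to be small against the scatter, and a limit rather than a number is a real possibility for compound 4.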

Compound 4, half-maximal effective concentration: 4400 nM
Compound 4: the middle estimate sits 2.7-fold (0.44 log units) above what was measured; measured number inside the range.
By their numbers in this assay, from the lowest: compound 4; then compounds 3 and 1 (each within the scatter of the next). At a limit, above all of these: compound 2.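

In this assay the change reads a 2.0-fold lower number from compound 3 to compound 4 (0.31 log units; beyond the scatter), which gives this position its first measured size, and that size lies beyond the scatter, though only modestly. Among these compounds, the direction is toward a lower number: with hydrogen in place of phenyl on a saturated chain carbon bound to an amine nitrogen in a ring, the benzyl on that amine is cut back to methyl, and the loss of the phenyl, with its six carbon atoms and its aromatic ring, costs nothing in this assay, whereas all the earlier steps touched only the group on the amide-type nitrogen. Nothing measured here accounts for the size or direction of this step.

Going by these compounds, only benzyl and methyl are seen at this place, so a single pair gives a direction and no trend, and whether an ethyl, a longer chain or a chain ending in a carboxylic acid would continue or reverse it remains open. Also open, on these data alone, is whether the same cut to methyl would act alike with a benzyl rather than an amino group on the amide-type nitrogen.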